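A few compounds are considered here, and "the series" means these few. Any claim that something is new, unique, unknown or untested is made for them only; others in the source may bear on it.

Of the compounds shown here, two have numbers so far in a functional assay on DU-145 cells (Homo sapiens) for inhibition, read by trypan blue exclusion, with a stated time of 96 h; on this read-out lower numbers stand for stronger inhibition of growth and higher numbers for weaker inhibition of growth. Compound 1 `COc1cc(/C=C(/Sc2ccc(Br)cc2)C(=O)c2ccc(Br)cc2)ccc1F` gives 10000 nM. Compound 2 `O=C(/C(=C\c1ccc(Cl)cc1)Sc1ccc(Br)cc1)c1ccc(Br)cc1` gives 1000 nM, the lower of the two numbers and therefore the stronger inhibition of growth.

Compound 3 `O=C(/C(=C\c1ccc(Cl)cc1Cl)Sc1ccc(Br)cc1)c1ccc(Br)cc1` differs from compound 2 in one place: chloro in place of hydrogen on an aromatic carbon. This turns 4-chlorophenyl into 2,4-dichlorophenyl, with the new chloro ortho to a large group and meta to the chloro group already present.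

Within the data shown here, the one measured step that bears on this change is a 10-fold lower number from compound 1 to compound 2 (1.00 log units; beyond the scatter). That modest step, beyond the scatter, touched the same part of the molecule, but it exchanged 4-fluoro-3-methoxyphenyl for 4-chlorophenyl. Among the measured compounds shown here, no measured compound shows what a chloro at the new place does, so the data point in no clear direction. In this assay, a single added chloro is therefore expected to give no step beyond the scatter. The estimated change is a 1.3-fold lower number from compound 2 to compound 3 (0.10 log units; within the scatter). For compound 3 the estimated value is 800 nM, with an expected range from 250 nM to 3000 nM.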

Compound 3, concentration for 50% growth inhibition: 1000 nM
Compound 3: the middle estimate sits 1.3-fold (0.10 log units) below what was measured; low and high end bracket the measured number.
By their numbers in this assay, from the lowest: compounds 2 and 3 (each within the scatter of the next); then compound 1.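

In this assay, a chloro placed ortho to a large group on the aromatic ring gives no change at the digits printed from compound 2 to compound 3 (within the scatter) and so leaves the number in the same range: this position takes one extra chlorine atom with no step beyond the scatter. The 2,4-dichlorophenyl group also holds on to the advantage over 4-fluoro-3-methoxyphenyl, giving a 10-fold lower number from compound 1 to compound 3 (1.00 log units; beyond the scatter) and matching in size the earlier 10-fold lower number from compound 1 to compound 2 (1.00 log units; beyond the scatter) for the 4-chlorophenyl group. Nothing available here accounts for this flat result or says what lies behind it.

On these data alone, only chloro has been seen at this place, so it remains open whether a different group there, such as an amine or a carboxylic acid, would shift the number beyond the scatter or whether this position tolerates such changes as well. As far as these compounds go, the rest of the core stays the same in all three compounds, so it is also open whether the same chloro would behave alike with a different group in place of either bromo.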